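From Methyl to Sec-Butyl on the Amide-Bearing Carbon

The source may hold more compounds than are shown below. What is called first, only, known or untested is meant among the compounds shown, and "the series" means these compounds.

Compound 1 `C[C@H](NC(=O)CN(c1nc(Cl)nc2[nH]cnc12)C1CC1)C(=O)OCc1ccccc1` is judged in a functional assay on the whole organism (Tail, strain ICR) with Mus musculus as the target, in the tail flick test, with a stated time of 90 min, at a dose of 25 umol/kg by the oral route; on this read-out higher numbers stand for a stronger effect at the one dose given and lower numbers for a weaker effect. Compound 1 gives 44.2%, the highest of the three numbers measured here. Compound 3 `O=C(CN(c1ncnc2c1ncn2C1CCCCO1)C1CC1)N[C@@H](CO)C(=O)OCc1ccccc1` comes nearest with 32.2%, and compound 2 `O=C(CN(c1ncnc2c1ncn2C1CCCCO1)C1CC1)N[C@@H](CCC(=O)OCc1ccccc1)C(=O)OCc1ccccc1` lies furthest with 25.2%; both gaps to compound 1 are beyond the scatter. Among the compounds with values here, the single measured step joins these two: a number 7 percentage points higher from compound 2 to compound 3 (within the scatter). Compound 4 `CC[C@H](C)[C@H](NC(=O)CN(c1nc(Cl)nc2[nH]cnc12)C1CC1)C(=O)OCc1ccccc1` differs from compound 1 in one place: sec-butyl in place of methyl on a saturated chain carbon bound to an amide-type nitrogen and a carbonyl carbon. Within the data shown here, no measured step touches this place or this exchange; the step from compound 2 to compound 3 concerns a different group on a different core, and it stayed within the scatter. Without a guide of that kind, no step beyond the scatter is expected in this assay from this change, in either direction. For compound 4 the expected value is therefore 40%, with a range from 20% to 60%. The step this estimate means, a number 4.2 percentage points lower from compound 1 to compound 4 (within the scatter), is expected to be small.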

Compound 4, a percentage reported as activity, at one dose (the size of the read-out at that dose, not a potency): 36.3%
The estimate for compound 4 lay 3.7 percentage points above the measured number; measured number inside the range.
By their numbers in this assay, from the lowest: compounds 2, 3, 4 and 1 (each within the scatter of the next, the first and the last beyond it).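

In this assay, putting sec-butyl in place of methyl on the saturated chain carbon bound to an amide-type nitrogen and a carbonyl carbon gives a number 7.9 percentage points lower from compound 1 to compound 4 (within the scatter). Within the data shown here, this is the first direct reading at this place: on the core of compound 1, a carbon group of 4 heavy atoms with 1 defined stereocentre cannot be told apart from methyl, with 1 heavy atom, at this single dose. No measurement shown here offers an explanation for this result.

As far as these compounds go, whether the same place also tolerates a group that is not purely carbon, such as a primary amine or a carboxylic acid, remains open. From the compounds shown here alone, it is also open whether a longer unbranched chain, such as n-hexyl, would stay within the scatter of compound 1.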